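Varying the aryl on the pyrazole: compound 4

A few compounds are considered here, and "the series" means these few. Any claim that something is new, unique, unknown or untested is made for them only; others in the source may bear on it.

The shared core of compound 1 `COc1cccc(-c2c(C)nn(-c3nc(-c4ccc(Cl)c(Cl)c4)c(SC(C)C)s3)c2C(=O)O)c1` carries an aryl group that has been exchanged across the set. In a functional assay on BJAB cells (Homo sapiens) for antiproliferative activity, with a stated time of 4 days (a lower number here means that less compound is needed, a higher number that more compound is needed for the effect), compound 1 gives 14000 nM. Compound 2 `COc1ccc(C)cc1-c1c(C)nn(-c2nc(-c3ccc(Cl)c(Cl)c3)c(SC(C)C)s2)c1C(=O)O` gives 9500 nM in this assay, and compound 3 `CCOc1ncccc1-c1c(C)nn(-c2nc(-c3ccc(Cl)c(Cl)c3)c(SC(C)C)s2)c1C(=O)O` gives 11000 nM. Compound 2 sits at the low end of these three numbers, but a 1.5-fold lower number from compound 1 to compound 2 (0.17 log units; within the scatter) and a 1.2-fold higher number from compound 2 to compound 3 (0.06 log units; within the scatter) both fall within the scatter, as does a 1.3-fold lower number from compound 1 to compound 3 (0.10 log units; within the scatter), so the three measured aryl variants cannot be told apart.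

Compound 4 `COc1cc(-c2c(C)nn(-c3nc(-c4ccc(Cl)c(Cl)c4)c(SC(C)C)s3)c2C(=O)O)cc(C(F)(F)F)c1` has not yet been measured. It differs from compound 2 at the same position: 3-methoxy-5-(trifluoromethyl)phenyl in place of 2-methoxy-5-methylphenyl on an aromatic carbon. Both measured steps at this position bear on it, and neither moved the number beyond the scatter, whether the ring carried a single methoxy, a methoxy with a methyl, or was exchanged for an ethoxypyridinyl. For the measured compounds named here, nothing in the set distinguishes one aryl from another, and no measured compound carries a trifluoromethyl, so the new group is an extrapolation. The expectation is therefore no step beyond the scatter, a 1.2-fold higher number from compound 2 to compound 4 (0.06 log units; within the scatter), with a wide range to cover the untested group. Compound 4 is estimated at 11000 nM in this assay, between 4500 nM and 27000 nM.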

Compound 4, half-maximal effective concentration: 1380 nM
Estimate against measurement, compound 4: 8.0-fold (0.90 log units) above; the whole stated range lies above it.
By their numbers in this assay, from the lowest: compound 4; then compounds 2, 3 and 1 (each within the scatter of the next).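

In this assay, for the compounds shown here, the aryl on the pyrazole no longer looks indifferent to exchange: a 6.9-fold lower number from compound 2 to compound 4 (0.84 log units; beyond the scatter) and an 8.0-fold lower number from compound 3 to compound 4 (0.90 log units; beyond the scatter) both lie beyond the scatter, whereas every step among the earlier compounds stayed within it. The most informative comparison is a 10-fold lower number from compound 1 to compound 4 (1.01 log units; beyond the scatter), a single change of trifluoromethyl in place of hydrogen on an aryl that already carries the methoxy, so in this pair the lower number goes with the added trifluoromethyl and not with the methoxy, which both compounds share. Nothing available on these compounds accounts for the size of this step, and the series data give only the numbers.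

The compounds shown leave open whether the trifluoromethyl is specifically required or whether a nitrile, a bromine or a pentafluorosulfanyl group in its place would give a similar step. They also leave open whether the methoxy contributes at all, a question that a 3-(trifluoromethyl)phenyl without it, or with an ethoxy or a hydroxy group instead, would address.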